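Swapping the ring-nitrogen substituent on a urea core

The source may report more compounds than this note shows. Statements on the series, on what has been measured and on what is new or still open speak of the compounds shown alone.

Measured so far:
- compound 1, `CC(C)(C)OC(=O)CN1CCc2c(sc(NC(=O)Nc3ccc(Cl)cc3)c2C(N)=O)C1`: > 25000 nM in a functional assay (strain AB) with Danio rerio as the target, read by microscopy, with a stated time of 1 h; a lower number here means that less compound is needed, a higher number that more compound is needed for the effect
- compound 2, `CC(C)(C)OC(=O)CCCCCN1CCc2c(sc(NC(=O)Nc3ccc(Cl)cc3)c2C(N)=O)C1`: 620 nM in this assay

Compound 1 sits at a limit of this assay: its value of > 25000 nM is not a number but the boundary at which the measurement stops (the limit of > 25000 nM in this assay, at which 1 of the 2 values shown sits). Going by the values given here, compound 2 gives a real number, 620 nM, and the only change between them is the substituent on the ring nitrogen of the shared core: an at least 40-fold lower number from compound 1 to compound 2 (1.60 log units; beyond the scatter). That single step shows that this position tolerates, and indeed rewards, a longer chain.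

Compound 3, `CC(C)N1CCc2c(sc(NC(=O)Nc3ccc(Cl)cc3)c2C(N)=O)C1`, is not yet measured. It differs from compound 1 as follows: isopropyl in place of (tert-butoxycarbonyl)methyl on an amine nitrogen in a ring. Among the compounds with values here, this change removes the ester entirely and leaves a small branched alkyl group; no measured step covers such a removal, so the large step from compound 1 to compound 2 is only loosely related. The expectation is a modest gain, so compound 3 is estimated at 6000 nM (range 1000 nM to 25000 nM), meaning an expected step of an at least 4.1-fold lower number from compound 1 to compound 3 (0.61 log units; beyond the scatter).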

Compound 3, half-maximal effective concentration: 1490 nM
The estimate for compound 3 lay 4.0-fold (0.60 log units) above the measured number; measured number inside the range.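

In this assay, replacing (tert-butoxycarbonyl)methyl with isopropyl gives an at least 16-fold lower number from compound 1 to compound 3 (1.22 log units; beyond the scatter), so the ester is not needed at this ring nitrogen for a measurable effect. A longer chain is also not the only route to a measurable value, and compound 3 goes against any simple rule that a longer chain is needed: compound 2, with its long ester chain, gives 620 nM, and compound 3, with a small branched alkyl group and no ester, gives 1490 nM. The true size of the step to compound 3 cannot be read, since the value for compound 1 is a limit and not a number: the limit of > 25000 nM in this assay, at which 1 of the 3 values shown sits.

As far as these compounds go, what holds compound 1 at its limit stays open, as this one change both removes the ester and replaces 8 heavy atoms with 3. Also open, from the compounds shown here alone, is how the shared core would respond to a plain unbranched hexyl chain, which would separate chain length from the ester, or to a carboxylic acid or an amine at the end of a chain on this nitrogen.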